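The source may hold more compounds than are shown below. What is called first, only, known or untested is meant among the compounds shown, and "the series" means these compounds.

In a functional assay on A549 cells (Homo sapiens) for inhibition, read by MTT assay, with a stated time of 72 h (a higher number here means a weaker inhibitor, a lower number a stronger inhibitor), compound 1 `CC(C)(C)n1cc2c(n1)C(=O)CC1(CCN(C(=O)c3cc(-c4ccccc4)nc4ccccc34)CC1)O2` gives 1940 nM, and compound 2 `COc1ccc(-c2cc(C(=O)N3CCC4(CC3)CC(=O)c3nn(C(C)(C)C)cc3O4)c3ccccc3n2)cc1OC` gives 2030 nM, so compound 2 cannot be separated from compound 1. Compound 3 `CC(C)(C)n1cc2c(n1)C(=O)CC1(CCN(C(=O)c3cc(-c4ccc(N)cc4)nc4ccccc34)CC1)O2` carries 4-aminophenyl in place of 3,4-dimethoxyphenyl, on the aromatic carbon next to the ring nitrogen: 4-aminophenyl in place of 3,4-dimethoxyphenyl on an aromatic carbon. Among the compounds with values here, the one measured step at this place, a 1.0-fold higher number from compound 1 to compound 2 (0.02 log units; within the scatter), stayed within the scatter, so no step beyond the scatter is expected in this assay, although no 4-aminophenyl compound has yet been measured. The expected step is a 1.2-fold lower number from compound 2 to compound 3 (0.08 log units; within the scatter). Compound 3 is estimated at 1700 nM, with an expected range from 650 nM to 4500 nM.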

Compound 3, half-maximal inhibitory concentration: 970 nM
For compound 3 the middle estimate is 1.8-fold (0.24 log units) above the measured one, and the stated range covers the measured number.
By their numbers in this assay, from the lowest: compounds 3, 1 and 2 (each within the scatter of the next, the first and the last beyond it).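

In this assay, within the data shown here, this aromatic carbon is no longer silent: 4-aminophenyl in place of 3,4-dimethoxyphenyl gives a 2.1-fold lower number from compound 2 to compound 3 (0.32 log units; beyond the scatter) and is the first step here beyond the scatter, though a modest one. Amino in place of hydrogen gives a 2.0-fold lower number from compound 1 to compound 3 (0.30 log units; within the scatter) and stays within the scatter, so compound 3 cannot be separated from compound 1. Nothing available explains the step from compound 2.

Going by these compounds, whether a hydroxyl or dimethylamino group in place of the amino group would give a similar number remains open.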